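The source may report more compounds than this note shows. Statements on the series, on what has been measured and on what is new or still open speak of the compounds shown alone.

Three compounds share one core and differ only in the group carried on the benzylic ring. Compound 1 `CCC(C)(C)/N=c1\c(O)c(O)\c1=N/Cc1ccc(C#N)cc1` gives 1100 nM in a functional assay for inhibition, with Rattus norvegicus as the target; on this read-out lower numbers stand for stronger inhibition and higher numbers for weaker inhibition. Compound 2 `CCC(C)(C)/N=c1\c(O)c(O)\c1=N/Cc1ccc(F)c(Cl)c1` gives 870 nM in this assay. Compound 3 `CCC(C)(C)/N=c1\c(O)c(O)\c1=N/Cc1ccc(SC)cc1` gives 5600 nM in this assay, the highest of the three numbers; compound 1 stands nearest to it and compound 2 furthest from it, both beyond the scatter.

Compound 4 `CCC(C)(C)/N=c1\c(O)c(O)\c1=N/Cc1ccc(F)cc1` has not yet been measured. It differs from compound 3 in one place: fluoro in place of methylsulfanyl on an aromatic carbon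

Going by the values given here, one measured step bears on this change. The step of a 5.1-fold higher number from compound 1 to compound 3 (0.71 log units; beyond the scatter) shows that bringing in methylsulfanyl in place of cyano raised the number; compound 4 removes that methylsulfanyl again. Among the compounds with values here, no step to compound 2 is given, but compound 2, which carries fluoro alongside chloro, gives 870 nM, a number close to that of compound 1 rather than to that of compound 3. On this basis compound 4 is expected to fall back toward the level of compound 1, because a 5.1-fold higher number from compound 1 to compound 3 (0.71 log units; beyond the scatter) ran the other way. Compound 4 is therefore expected to show a 4.7-fold lower number from compound 3 to compound 4 (0.67 log units; beyond the scatter). The estimate for compound 4 in this assay is 1200 nM, with a range from 500 nM to 3000 nM.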

Compound 4, half-maximal inhibitory concentration: 360 nM
The estimate for compound 4 lay 3.3-fold (0.52 log units) above the measured number; the whole stated range lies above it.
By their numbers in this assay, from the lowest: compound 4; then compounds 2 and 1 (each within the scatter of the next); then compound 3.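

In this assay, going by these compounds alone, the aromatic carbon para to a large group proves more sensitive than the earlier compounds showed, with fluoro in place of methylsulfanyl giving a 16-fold lower number from compound 3 to compound 4 (1.19 log units; beyond the scatter) and so a wider span than the one between cyano and methylsulfanyl. Fluoro also outdoes cyano at this place, with a 3.1-fold lower number from compound 1 to compound 4 (0.49 log units; beyond the scatter) as the result, which takes the series below the level at which compounds 1 and 2 stand within the scatter of each other. The chloro of compound 2 is not needed for a low number either: hydrogen in place of chloro gives a 2.4-fold lower number from compound 2 to compound 4 (0.38 log units; beyond the scatter) and compound 4, with its steps to all three others beyond the scatter, is the strongest inhibitor of the four.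

Within the data shown here, only three groups stand alone at this place, so it remains open whether chloro alone, a methoxy group, an amine or a carboxylic acid there would follow fluoro or methylsulfanyl. Nothing measured alongside these numbers bears on why they move with these groups.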